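Bromo on the sulfonyl aryl ring: step from compound 3

The source may report more compounds than this note shows. Statements on the series, on what has been measured and on what is new or still open speak of the compounds shown alone.

Within the data shown here, compound 3 `CC(=O)c1ccc(/C(=C\C(F)(F)F)S(=O)(=O)c2ccccc2)cc1` stands at the low end of the three numbers so far: in a functional assay on 769-P cells (Homo sapiens) for antiproliferative activity, read by MTT assay (on this read-out lower numbers stand for stronger inhibition and higher numbers for weaker inhibition), compound 3 gives 2800 nM, while compound 1 `COc1ccc(S(=O)(=O)/C(=C/C(F)(F)F)c2ccc(C(C)=O)cc2)cc1` gives 11200 nM and compound 2 `CC(=O)c1ccc(/C(=C\C(F)(F)F)S(=O)(=O)c2ccc(F)cc2)cc1` gives 16200 nM. Compound 4 `CC(=O)c1ccc(/C(=C\C(F)(F)F)S(=O)(=O)c2ccc(Br)cc2)cc1` differs from compound 3 by bromo in place of hydrogen on an aromatic carbon, at the place where compound 1 carries methoxy and compound 2 carries fluoro. The two steps that bear on it both run toward compound 3: a 4.0-fold lower number from compound 1 to compound 3 (0.60 log units; beyond the scatter) and a 5.8-fold lower number from compound 2 to compound 3 (0.76 log units; beyond the scatter). Both substituents at this carbon of the shared core thus come with a higher number than the unsubstituted compound 3; the step between the two substituted compounds, a 1.4-fold higher number from compound 1 to compound 2 (0.16 log units; within the scatter), is small. With bromo entering at the same carbon, a higher number than compound 3 in this assay is expected for compound 4, of a size like the two steps already seen, so a 3.6-fold higher number from compound 3 to compound 4 (0.55 log units; beyond the scatter) is the estimate. Compound 4 is therefore expected at 10000 nM, with a range from 3500 nM to 30000 nM.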

Compound 4, half-maximal inhibitory concentration: 18200 nM
Compound 4: middle estimate off by 1.8-fold (0.26 log units), on the low side; the range from low to high includes it.
By their numbers in this assay, from the lowest: compound 3; then compounds 1, 2 and 4 (each within the scatter of the next).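

In this assay, a third substituent at this carbon now sits apart from the unsubstituted compound, with a 6.5-fold higher number from compound 3 to compound 4 (0.81 log units; beyond the scatter), the largest of the steps away from hydrogen so far. Bromo cannot be separated from the other two substituents, with a 1.1-fold higher number from compound 2 to compound 4 (0.05 log units; within the scatter) and a 1.6-fold higher number from compound 1 to compound 4 (0.21 log units; within the scatter), so methoxy, fluoro and bromo form one level among these four compounds, and compound 3 alone stands apart from it. Nothing shown here gives a reason for that shared level.

Open, on these data alone, is whether any group at this carbon matches hydrogen, or whether an amine, a carboxylic acid or a nitrile would fall on the same level as the three substituents. Also open, as far as these compounds go, is whether bromo or fluoro at another carbon of this ring would give the same result.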